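Urea to benzamide on the shared core: compound 4

The source may hold more compounds than are shown below. What is called first, only, known or untested is meant among the compounds shown, and "the series" means these compounds.

Compound 1 `COc1cc(Cl)cc(-c2nn(-c3cccc(NC(=O)Nc4cccc(C(F)(F)F)c4)c3)cc2-c2ccncc2)c1` is the reference point of the set. In a functional assay on ACHN cells (Homo sapiens) for inhibition, read by sulforhodamine B assay, with a stated time of 48 h, tested at 10 uM (on this read-out higher numbers stand for a weaker effect at the one concentration tested and lower numbers for a stronger effect), compound 1 gives 5.44%, the lowest of the three numbers measured. Compound 2 `COc1cc(Cl)cc(-c2nn(-c3cccc(NC(=O)Nc4ccc(Cl)c(C(F)(F)F)c4)c3)cc2-c2ccncc2)c1` gives 8.78%, and the step of a number 3.3 percentage points higher from compound 1 to compound 2 (within the scatter) is within the scatter. Within the data shown here, compound 3 `COc1cc(Cl)cc(-c2nn(-c3cccc(NC(=O)c4cc(C(F)(F)F)cc(C(F)(F)F)c4)c3)cc2-c2ccncc2)c1` gives 58.2%, far above compound 1; no single-point step connects these two, so the pair shows only that compound 3 sits well beyond the scatter from compound 1.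

Compound 4 `COc1cc(Cl)cc(-c2nn(-c3cccc(NC(=O)c4cccc(C(F)(F)F)c4)c3)cc2-c2ccncc2)c1` differs from compound 1 in one place: 3-(trifluoromethyl)phenyl in place of (3-(trifluoromethyl)phenyl)amino on a carbonyl carbon. Among the measured compounds shown here, the only measured single step, from compound 1 to compound 2, concerns a chloro on an aromatic carbon and does not touch the carbonyl carbon, so it carries no information on this change. The closest measured guide is compound 3, which also holds a carbonyl carbon bearing an aryl rather than an arylamino group, and whose number is much higher than that of compound 1; but compound 3 differs from compound 4 in its aryl substitution as well, so it sets only a loose upper reference.

The expectation for compound 4 is therefore a weaker effect than compound 1, with the step of a number 32.6 percentage points higher from compound 1 to compound 4 (beyond the scatter) estimated to lie beyond the scatter but short of compound 3. Compound 4 is expected to give about 38%, within 10% to 70%.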

Compound 4, a percentage reported as activity, at one concentration (the size of the read-out at that concentration, not a potency): 48.1%
Compound 4: middle estimate off by 10.1 percentage points, on the low side; low and high end bracket the measured number.
By their numbers in this assay, from the lowest: compounds 1 and 2 (each within the scatter of the next); then compound 4; then compound 3.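

The nitrogen of the (3-(trifluoromethyl)phenyl)amino group on the carbonyl carbon proves to matter for the effect in this assay: replacing that group with 3-(trifluoromethyl)phenyl gives a number 42.7 percentage points higher from compound 1 to compound 4 (beyond the scatter), and the corresponding comparison with the chloro-bearing urea gives a number 39.3 percentage points higher from compound 2 to compound 4 (beyond the scatter), so the weaker effect appears with or without the chloro. Hydrogen in place of trifluoromethyl on an aromatic carbon of the carbonyl-linked aryl gives a number 10.1 percentage points lower from compound 3 to compound 4 (beyond the scatter), a modest step that shows substitution on this aryl still shifts the number in the absence of the urea nitrogen, though by much less than the steps from the two ureas. No measurement here explains why the urea and the aryl carbonyl differ.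

On these data alone, it remains open whether the nitrogen itself or its hydrogen carries the difference, which a methylated urea nitrogen, a methylene or an ether oxygen at that place on the carbonyl carbon could separate. Also open, as far as these compounds go, is whether a nitrile or a methoxy group in place of trifluoromethyl would keep the low number of the urea compounds.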